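Growing the Chain on the Shared Core of Compound 1

This account rests on a few compounds, and the source may have more. Where it says the series, first, only, none or still open, it means among the compounds named here.

Measured so far:
compound 1 `Cc1ccc(NC(=O)N[C@H](C)c2ccccc2)cc1`: 98%
compound 2 `CCc1ccccc1NC(=O)N[C@H](C)c1ccccc1`: 100%
compound 3 `C[C@H](NC(=O)Nc1ccc(C(C)(C)C)cc1)c1ccccc1`: 88%

All three compounds were tested in an ADME assay on the whole organism with Oryza sativa as the target, tested at 1 uM; a higher number here means a weaker effect of the compound at the concentration tested, a lower number a stronger effect. In this assay compound 1 gives 98%, compound 2 gives 100% and compound 3 gives 88%. These three numbers lie within the usual scatter of one another, so compound 1 sits among them without a separable place of its own.

The compound still to be measured is compound 4 `CCCCc1ccc(NC(=O)N[C@H](C)c2ccccc2)cc1`. It differs from compound 1 by one change: propyl in place of hydrogen on a saturated chain carbon bound to an aromatic carbon. Among the compounds with values here, nothing among the measured compounds shows how a change of this kind moves this assay. Within the data shown here, since the three known numbers lie so close, no step beyond the scatter is expected, and the estimated step from compound 1 to compound 4 is a number 3 percentage points lower from compound 1 to compound 4 (within the scatter). Compound 4 is therefore expected to give about 95%, between 80% and 100%.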

Compound 4, a percentage reported as activity, at one concentration (the size of the read-out at that concentration, not a potency): 32%
The estimate for compound 4 lay 63 percentage points above the measured number, outside the stated range (below it).
By their numbers in this assay, from the lowest: compound 4; then compounds 3, 1 and 2 (each within the scatter of the next, the first and the last beyond it).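

In this assay the change of methyl to butyl gives a number 66 percentage points lower from compound 1 to compound 4 (beyond the scatter) and so marks the first clear movement in this small set. Within the data shown here, this saturated chain carbon bound to an aromatic carbon is therefore a place where adding propyl can strongly change the read-out, which the earlier compounds, with no step linking them, could not show. No available data explain why the number falls at this place.

A single step cannot show whether a longer chain such as hexyl would lower the number further or reverse the change. It also leaves open whether a carboxylic acid or an amine at the chain end would keep the effect.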